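Replacing a Short Chain with a Trifluoromethoxyphenyl Arm

A few compounds are considered here, and "the series" means these few. Any claim that something is new, unique, unknown or untested is made for them only; others in the source may bear on it.

Measured so far:
- compound 1, `CCCCCCc1cn(C(c2ccccc2)c2cc3cc(Br)ccc3nc2OC)nn1`, in an ADME assay on PC-3 cells (Homo sapiens) for cytotoxicity, read by sulforhodamine B assay, with a stated time of 48 h, tested at 10 uM (on this read-out lower numbers stand for less inhibition and higher numbers for more inhibition at the one concentration tested (going by the name of the read-out)), gives 2.32%
- compound 2, `CCCCCCCCc1cn(C(c2ccccc2)c2cc3cc(Br)ccc3nc2OC)nn1`, gives 2.27%
- compound 3, `CCCc1cn(C(c2ccccc2)c2cc3cc(Br)ccc3nc2OC)nn1`, gives 8.3%

All three share the same core and differ only in the chain on one carbon of the five-membered ring with three nitrogens. Among the compounds with values here, on the numbers so far, compound 3 is not set apart from the others: the steps of a number 6 percentage points higher from compound 1 to compound 3 (within the scatter) and a number 6 percentage points higher from compound 2 to compound 3 (within the scatter) both lie within the usual scatter, as does a number 0.1 percentage points lower from compound 1 to compound 2 (within the scatter).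

Compound 4, `COc1nc2ccc(Br)cc2cc1C(c1ccccc1)n1cc(-c2ccc(OC(F)(F)F)cc2)nn1`, departs from compound 3 by 4-(trifluoromethoxy)phenyl in place of propyl on an aromatic carbon. The measured steps only lengthen or shorten a saturated chain at this position, and none of them moved the number beyond the scatter. Within the data shown here, no measured step exchanges a chain for an aromatic ring, so the new group is untested ground, and the expectation rests on the flat behaviour seen so far.

The expected step is therefore a number 0.3 percentage points lower from compound 3 to compound 4 (within the scatter), no change beyond the scatter, with a wider range to allow for the untested ring. Compound 4 is estimated at 8%, between 0% and 28%.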

Compound 4, a percentage reported as inhibition, at one concentration (the size of the read-out at that concentration, not a potency): 21.6%
For compound 4 the middle estimate is 13.6 percentage points below the measured one; measured number inside the range.
By their numbers in this assay, from the lowest: compounds 2, 1 and 3 (each within the scatter of the next); then compound 4.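

Within the data shown here, exchanging propyl for 4-(trifluoromethoxy)phenyl gives a number 13.3 percentage points higher from compound 3 to compound 4 (beyond the scatter) in this assay and is the first change at this position to go beyond the scatter, so the carbon of the five-membered ring is not indifferent to what it carries. The same holds against the longer chains, with a number 19.3 percentage points higher from compound 1 to compound 4 (beyond the scatter) on replacing hexyl and a number 19.3 percentage points higher from compound 2 to compound 4 (beyond the scatter) on replacing octyl, which sets compound 4 apart from all three chain compounds. Nothing measured here explains this difference.

Going by these compounds, it remains open whether the aromatic ring alone accounts for the higher number or whether the trifluoromethoxy group contributes, a question that plain phenyl or 4-methoxyphenyl at this carbon could help settle. Also open, on these data alone, is how an amine or a carboxylic acid on that ring would behave.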